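The compounds below may be only part of what the source reports. "The series", "measured", "known", "first", "only" and "open" are said of these compounds alone.

Of the compounds shown here, three built on one shared core have been measured in an assay (Rattus norvegicus) for inhibition of Fatty-acid amide hydrolase 1 (Homo sapiens); on this read-out higher numbers stand for weaker inhibition and lower numbers for stronger inhibition. Compound 1 `COc1ccc(-c2cnc(C(=O)CCCCCCc3ccccc3)o2)cc1` gives 100 nM. Compound 2 `O=C(CCCCCCc1ccccc1)c1ncc(-c2ccc(C(=O)C(F)(F)F)cc2)o1` gives 65 nM. Compound 3 `Cc1cccnc1-c1cnc(C(=O)CCCCCCc2ccccc2)o1` gives 15 nM, the lowest of the three numbers, and its gaps to both of the others lie beyond the scatter. Comparing the two changes made so far: a 1.5-fold lower number from compound 1 to compound 2 (0.19 log units; within the scatter), whereas a 6.7-fold lower number from compound 1 to compound 3 (0.82 log units; beyond the scatter).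

Compound 4 `O=C(CCCCCCc1ccccc1)c1ncc(I)o1` differs from compound 3 in one place: iodo in place of 3-methylpyridin-2-yl on an aromatic carbon. Neither measured step covers this kind of change. Both of them keep a six-membered aromatic ring at that place and alter only what that ring carries, while here the whole ring gives way to iodo. The step of a 6.7-fold lower number from compound 1 to compound 3 (0.82 log units; beyond the scatter) shows that what sits at this place can move the number beyond the scatter, so a shift of comparable size is plausible, and since the group that went with the lowest number is the one removed, a higher number is more likely than a lower one. Compound 4 is therefore expected to give 400 nM, with a range from 80 nM to 2000 nM. That estimate means the step of a 27-fold higher number from compound 3 to compound 4 (1.43 log units; beyond the scatter), expected to lie beyond the scatter but stated with wide uncertainty.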

Compound 4, inhibition constant: 3 nM
Compound 4: middle estimate off by 130-fold (2.12 log units), on the high side, outside the stated range (below it).
By their numbers in this assay, from the lowest: compound 4; then compound 3; then compounds 2 and 1 (each within the scatter of the next).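

In this assay, the six-membered aromatic ring at this place turns out not to be required for a low number: iodo, with 1 heavy atom where 3-methylpyridin-2-yl had 7, gives a 5.0-fold lower number from compound 3 to compound 4 (0.70 log units; beyond the scatter) and so goes beyond the best ring shown. For the compounds shown here, the same replacement measured against the 4-methoxyphenyl group gives a 33-fold lower number from compound 1 to compound 4 (1.52 log units; beyond the scatter) and is a large step, so on this carbon, next to the ring oxygen, both rings compared directly with iodo give higher numbers than iodo does, and the earlier compounds, which all carried a ring here, could not reveal this. Nothing available explains why the number falls when the ring is removed.

The compounds shown leave open whether the low number belongs to iodine in particular or to any group with few heavy atoms, a question that chloro, bromo, methyl, nitrile or a bare hydrogen at this carbon would help to settle. They also leave open whether the gain from iodo would persist if the phenyl-ending chain on the carbonyl were shortened or lengthened.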